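Benzyl Substituent Swap on a Shared Nucleoside Core

The compounds below may be only part of what the source reports. "The series", "measured", "known", "first", "only" and "open" are said of these compounds alone.

Measured compounds:
- compound 1, `Cc1cccc(CNc2ncnc3c2ncn3[C@@H]2O[C@H](CO)[C@@H](O)[C@H]2O)c1`: > 166000 nM
- compound 2, `COc1ccccc1CNc1ncnc2c1ncn2[C@@H]1O[C@H](CO)[C@@H](O)[C@H]1O`: > 166000 nM
- compound 3, `COc1cc(CNc2ncnc3c2ncn3[C@@H]2O[C@H](CO)[C@@H](O)[C@H]2O)cc(OC)c1`: "not determined" (no result reported)

In a functional assay on HOS cells (Homo sapiens) for antiproliferative activity, with a stated time of 72 h (a higher number here means a weaker inhibitor, a lower number a stronger inhibitor), compound 1 gives > 166000 nM, which is a limit of the assay and not a number. In this assay compound 2 gives > 166000 nM, again a limit. For compound 3 no result is reported in this assay, so it cannot be placed on the scale; the two values shown for the other compounds both sit at a limit, as the limit of > 166000 nM in this assay, at which 2 of the 3 values shown sit, states. The step that the two limits leave unreadable from compound 1 to compound 2 is therefore unreadable in size.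

Compound 4 is `OC[C@H]1O[C@@H](n2cnc3c(NCc4cccc(C(F)(F)F)c4)ncnc32)[C@H](O)[C@@H]1O`. It differs from compound 3 as follows: 3-(trifluoromethyl)phenyl in place of 3,5-dimethoxyphenyl on a saturated chain carbon bound to a nitrogen on an aromatic ring. Within the data shown here, no measured step concerns a trifluoromethyl-bearing ring, and the only measured pair gives no readable size. The two measured values both sit at the limit, so compound 4 is expected to remain there as well. The expected value for compound 4 in this assay is 200000 nM, with a range from 50000 nM to 600000 nM.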

Compound 4, half-maximal inhibitory concentration: > 166000 nM
Compound 4 gave a limit, no number; the forecaster's own chance of this, stated with the estimate: 80%; the middle value lies beyond the limit too.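

Compound 1, compound 2 and compound 4 all sit at a limit rather than a number, so no step among them can be read in this assay: the limit of > 166000 nM in this assay, at which 3 of the 4 values shown sit.

The compounds shown leave open whether any other group on this aromatic ring would give a readable number in this assay.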